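Bromophenyl Sulfonamide Judged From Two Neighbours at the Limit

The source may report more compounds than this note shows. Statements on the series, on what has been measured and on what is new or still open speak of the compounds shown alone.

Compound 1 `CCN(CC)C(=O)CN(c1ccc(C)cc1)S(=O)(=O)c1ccc(C#N)cc1` carries 4-cyanophenyl on its sulfonyl sulfur. In a functional assay on CHO cells for inhibition of Orexin/Hypocretin receptor type 1 (Homo sapiens), read by FLIPR and calcium flux (a higher number here means a weaker inhibitor, a lower number a stronger inhibitor), compound 1 gives > 10000 nM, which is a limit of the assay rather than a number. Compound 2 `CCN(CC)C(=O)CN(c1ccc(C)cc1)S(=O)(=O)c1ccccc1C` carries 2-methylphenyl in that place. In this assay compound 2 gives > 10000 nM, again a limit and not a number. The step that the two limits leave unreadable from compound 1 to compound 2 therefore cannot be read for size or direction. For the measured compounds named here, compound 2 thus stands only at a limit, with no measured number of its own, and the one further value shown is likewise a limit. Compound 3 `CCN(CC)C(=O)CN(c1ccc(C)cc1)S(=O)(=O)c1ccc(Br)cc1` differs from compound 2 in one place: 4-bromophenyl in place of 2-methylphenyl on a sulfonyl sulfur. Going by the values given here, no measured step bears directly on this exchange, so nothing sets a readable size or direction for it. What is known is summarised by the limit of > 10000 nM in this assay, at which 2 of the 2 values shown sit, and on that basis compound 3 is expected to sit at or near the same limit. The expected step is a step that the limit leaves unreadable from compound 2 to compound 3. Compound 3 is estimated at 15000 nM, with a range from 3000 nM to 60000 nM.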

Compound 3, half-maximal inhibitory concentration: > 10000 nM
Compound 3: no number, only a limit; the forecaster's own chance of this, stated with the estimate: 80%; the middle value is on the limit's open side.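

Compound 3 also stands at a limit of the assay rather than at a number, so its steps from compound 1 and from compound 2 cannot be read for size or direction: the limit of > 10000 nM in this assay, at which 3 of the 3 values shown sit.

The compounds shown leave open whether any group on the sulfonyl sulfur of this shared core can give a measured number in this assay, and how such groups would rank.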